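A few compounds are considered here, and "the series" means these few. Any claim that something is new, unique, unknown or untested is made for them only; others in the source may bear on it.

Compound 1, `CCn1c(C(=O)NCCCN(C)C)ccc1C(CC)(CC)c1ccc(OCC(O)C(C)(C)C)c(C)c1`: 37 nM
Compound 2, `CCn1c(C(=O)N(C)c2ccccc2)ccc1C(CC)(CC)c1ccc(OCC(O)C(C)(C)C)c(C)c1`: 6400 nM
Compound 3, `CCn1c(C(=O)N(CCC#N)CCC#N)ccc1C(CC)(CC)c1ccc(OCC(O)C(C)(C)C)c(C)c1`: 97 nM

In an assay on HL-60 cells for agonist activity at vitamin D3 receptor (Homo sapiens), read by microscopy, with a stated time of 96 h (a higher number here means that more compound is needed for the effect, a lower number that less compound is needed), compound 3 gives 97 nM, the second highest of the three numbers. The steps around it are a 2.6-fold higher number from compound 1 to compound 3 (0.42 log units; beyond the scatter) and a 66-fold lower number from compound 2 to compound 3 (1.82 log units; beyond the scatter). Compound 4, `CCOC(=O)c1ccc(OC(=O)c2ccc(C(CC)(CC)c3ccc(OCC(O)C(C)(C)C)c(C)c3)n2CC)cc1`, differs from compound 3 by a group of 12 heavy atoms (9 carbon, 3 oxygen; one six-membered aromatic ring of carbon only) in place of a group of 9 heavy atoms (6 carbon, 3 nitrogen; no ring), on a carbonyl carbon. The group that enters carries a six-membered aromatic ring, and among the measured compounds only compound 2 has such a ring on the carbonyl carbon. The two steps that bear on this are a 170-fold higher number from compound 1 to compound 2 (2.24 log units; beyond the scatter) and a 66-fold lower number from compound 2 to compound 3 (1.82 log units; beyond the scatter), both large, and both place the ring-bearing compound at the higher number. A large rise is therefore expected for compound 4, a 26-fold higher number from compound 3 to compound 4 (1.41 log units; beyond the scatter). Compound 4 is estimated at 2500 nM, with a range from 300 nM to 20000 nM.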

Compound 4, half-maximal effective concentration: > 50000 nM
Compound 4 ended at the assay's limit (the forecaster's own chance of this, stated with the estimate: 15%); middle value at least 20-fold (1.30 log units) away from the limit.
By their numbers in this assay, from the lowest: compound 1; then compound 3; then compound 2. At a limit, above all of these: compound 4.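

In this assay compound 4 gives > 50000 nM, which is a limit and not a number: the limit of > 50000 nM in this assay, at which 1 of the 4 values shown sits. Placing 4-(ethoxycarbonyl)phenoxy on this carbonyl carbon gives an at least 510-fold higher number from compound 3 to compound 4 (2.71 log units; beyond the scatter) and an at least 1300-fold higher number from compound 1 to compound 4 (3.13 log units; beyond the scatter), so this group stands above both chains without a ring. The other ring-bearing group, methyl(phenyl)amino, also stays apart, with an at least 7.8-fold higher number from compound 2 to compound 4 (0.89 log units; beyond the scatter), so having a six-membered aromatic ring here does not by itself set the level.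

The compounds shown do not separate the effect of the ring from that of the ethoxycarbonyl group or the linking oxygen. A plain phenoxy group, or a carboxylic acid in place of the ethoxycarbonyl group, would test this.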